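Moving the Pyridine Nitrogen on a Shared Core

The source may hold more compounds than are shown below. What is called first, only, known or untested is meant among the compounds shown, and "the series" means these compounds.

Compound 1 `O=c1c(-c2nnc(-c3ccc(F)cc3)o2)c[nH]c2ncc(-c3cccnc3)cc12` and compound 2 `O=c1c(-c2nnc(-c3ccc(Cl)cc3)o2)c[nH]c2ncc(-c3cccnc3)cc12` share one core and differ only in a halogen. In a functional assay on HCT-116 cells (Homo sapiens) for positive allosteric modulation, read by MTT assay, with stated times of 24 h and 48 h, tested at 2.5 uM (on this read-out lower numbers stand for less inhibition of growth and higher numbers for more inhibition of growth at the one concentration tested), compound 1 gives 20.1% and compound 2 gives 20.1%; the step of no change at the digits printed from compound 1 to compound 2 (within the scatter) leaves the two level. Within the data shown here, compound 1 thus stands level with its only measured neighbour, compound 2, and nothing in these numbers sets it apart.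

Compound 3 `O=c1c(-c2nnc(-c3ccc(F)cc3)o2)c[nH]c2ncc(-c3ccncc3)cc12` awaits measurement. It differs from compound 1 in this way: pyridin-4-yl in place of pyridin-3-yl on an aromatic carbon. Among the measured compounds shown here, no measured step touches this change; the single recorded step, from compound 1 to compound 2, altered another part of the molecule and was flat. The effect of the new change in this assay is therefore unknown, and the expectation is a step of no more than the scatter, a number 0.1 percentage points lower from compound 1 to compound 3 (within the scatter). For compound 3 in this assay the estimate is 20%, with a range from 8% to 35%.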

Compound 3, percent growth inhibition at one concentration: 19.6%
The estimate for compound 3 lay 0.4 percentage points above the measured number, within the range that was stated.
By their numbers in this assay, from the lowest: compounds 3, 1 and 2 (each within the scatter of the next).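

Placing pyridin-4-yl in place of pyridin-3-yl on this aromatic carbon of the shared core gives, in this assay, a number 0.5 percentage points lower from compound 1 to compound 3 (within the scatter), the first step measured at this position. At the one concentration tested, the read-out therefore does not separate these two pyridine attachments, even though the two groups hold the same atoms joined differently. No measurement shown here offers an explanation for this flat step.

The compounds shown leave open whether pyridin-2-yl, a plain phenyl ring or a morpholine on this same carbon would give a step beyond the scatter. They also leave open whether compound 1 and compound 3 would stay level at other concentrations, since only a single concentration is reported here.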